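A few compounds are considered here, and "the series" means these few. Any claim that something is new, unique, unknown or untested is made for them only; others in the source may bear on it.

Going by the values given here, in a functional assay on HUVEC cells (Homo sapiens) for inhibition, read by microscopy and crystal violet staining, with a stated time of 20 h (a higher number here means a weaker inhibitor, a lower number a stronger inhibitor), compound 1 (`COc1cc(C2Oc3cc(-c4oc5cc(O)cc(O)c5c(=O)c4OC)ccc3OC2CO)ccc1O`) gives 11300 nM and holds the lower of the two numbers so far, while compound 2 (`COc1cc(C2Oc3cc(-c4oc5cc(O)cc(O)c5c(=O)c4OC(=O)c4cc(O)c(O)c(O)c4)ccc3OC2CO)ccc1O`) gives 36800 nM as the only comparison. Compound 3 (`COCC1Oc2ccc(-c3oc4cc(O)cc(O)c4c(=O)c3OC)cc2OC1c1ccc(O)c(OC)c1`) carries methoxymethyl where compound 1 has hydroxymethyl (methyl in place of hydrogen on an oxygen on a saturated carbon). Among the compounds with values here, the one measured step (a 3.3-fold higher number from compound 1 to compound 2 (0.51 log units; beyond the scatter)) was modest and sits at a different place, on an oxygen on an aromatic ring, so it bears only indirectly. The expected step is therefore small and within the scatter (a 1.2-fold higher number from compound 1 to compound 3 (0.06 log units; within the scatter)). For compound 3 the estimated value is 13000 nM with an expected range of 5500 nM to 32000 nM in this assay.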

Compound 3, half-maximal inhibitory concentration: 10900 nM
The estimate for compound 3 lay 1.2-fold (0.08 log units) above the measured number, within the range that was stated.
By their numbers in this assay, from the lowest: compounds 3 and 1 (each within the scatter of the next); then compound 2.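

The swap of hydroxymethyl to methoxymethyl gives a 1.0-fold lower number from compound 1 to compound 3 (0.02 log units; within the scatter) in this assay, so the two compounds read alike. Going by these compounds alone, this is the first reading on an oxygen on a saturated carbon, and it shows that a methyl can stand on that oxygen with the number staying within the scatter. Nothing available offers an explanation for this result. As far as these compounds go, whether a longer chain on that oxygen, or an amine or a carboxylic acid at this place, would read alike remains open, since one methyl cannot speak for them.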